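The compounds below may be only part of what the source reports. "The series", "measured", "known", "first", "only" and "open" are said of these compounds alone.

Three compounds in this series share one core and differ only in the group carried on a single aromatic carbon. Compound 1 `COc1cccc(-c2ccc([C@H]3S[C@@H](C)C(=O)Nc4c3c(C)nn4-c3ccccc3C)cc2)c1` gives 1800 nM in an assay on isolated protein for agonist activity at Bile acid receptor (Homo sapiens), read by AlphaScreen, with a stated time of 30 min; on this read-out higher numbers stand for an effect only at larger amounts of compound and lower numbers for an effect already at smaller amounts; compound 2 `COc1ccccc1-c1ccc([C@H]2S[C@@H](C)C(=O)Nc3c2c(C)nn3-c2ccccc2C)cc1` gives 1100 nM; compound 3 `COc1cccc(Oc2ccc([C@H]3S[C@@H](C)C(=O)Nc4c3c(C)nn4-c3ccccc3C)cc2)c1` gives 1700 nM. Compound 3 thus stands second highest of the three, yet within the scatter of both others, as the steps of a 1.1-fold lower number from compound 1 to compound 3 (0.02 log units; within the scatter) and a 1.5-fold higher number from compound 2 to compound 3 (0.19 log units; within the scatter) show. Compound 4 `COc1ccccc1Oc1ccc([C@H]2S[C@@H](C)C(=O)Nc3c2c(C)nn3-c2ccccc2C)cc1` carries 2-methoxyphenyl in place of 3-methoxyphenyl on an oxygen on an aromatic ring. Among the compounds with values here, the one measured step that bears on this change is a 1.6-fold lower number from compound 1 to compound 2 (0.21 log units; within the scatter), the same methoxyphenyl swap made directly on the aromatic carbon. For compound 4 a step of about a 1.4-fold lower number from compound 3 to compound 4 (0.15 log units; within the scatter) is therefore expected, not beyond the scatter. The estimate for compound 4 is 1200 nM, with a range of 600 nM to 2500 nM.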

Compound 4, half-maximal effective concentration: 1700 nM
The estimate for compound 4 lay 1.4-fold (0.15 log units) below the measured number, and the stated range covers the measured number.
By their numbers in this assay, from the lowest: compounds 2, 3, 4 and 1 (each within the scatter of the next).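

On the oxygen, 2-methoxyphenyl in place of 3-methoxyphenyl leaves no readable difference in this assay (no change at the digits printed from compound 3 to compound 4 (within the scatter)), matching what the same swap did on the aromatic carbon. Changing the direct attachment to the phenoxy form is also unreadable, whether the methoxy group is kept as in (a 1.5-fold higher number from compound 2 to compound 4 (0.19 log units; within the scatter)) or changed as in (a 1.1-fold lower number from compound 1 to compound 4 (0.02 log units; within the scatter)). No measurement on hand accounts for this flat result. The compounds shown leave open whether any group here moves the number beyond the scatter, such as an amine or a carboxylic acid in place of the methoxy group.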